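This account rests on a few compounds, and the source may have more. Where it says the series, first, only, none or still open, it means among the compounds named here.

Compound 3 `CCC(C)(C)Cc1c[nH]c(CCc2ccc(-c3csnn3)cc2)n1` gives the lowest number of the three in an in vitro assay on CHO cells for displacement of a labelled ligand from Bombesin receptor subtype-3 (Homo sapiens), read by scintillation counting, with a stated time of 2 h (on this read-out higher numbers stand for weaker inhibition and lower numbers for stronger inhibition), at 45 nM; compound 1 `CCC(C)(C)Cc1c[nH]c(CCc2ccc(-c3ccncc3)cc2)n1` gives 101 nM and compound 2 `CCC(C)(C)Cc1c[nH]c(CCc2ccc(-n3ccnn3)cc2)n1` gives 390 nM. Compound 4 `CCC(C)(C)Cc1c[nH]c(CCc2ccc(-c3cccnc3C(=O)O)cc2)n1` carries 2-carboxypyridin-3-yl in place of 1,2,3-thiadiazol-4-yl on an aromatic carbon. For the measured compounds named here, the relevant steps are a 2.2-fold lower number from compound 1 to compound 3 (0.35 log units; beyond the scatter) and an 8.7-fold lower number from compound 2 to compound 3 (0.94 log units; beyond the scatter), so the six-membered aromatic ring of compound 1 sat a modest step above compound 3 and the swap back toward such a ring should cost something; the added carboxylic acid has no precedent. Compound 4 is therefore expected to show a modest rise, a 4.0-fold higher number from compound 3 to compound 4 (0.60 log units; beyond the scatter), landing near compound 1. The estimate for compound 4 in this assay is 180 nM, with a range of 50 nM to 700 nM.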

Compound 4, half-maximal inhibitory concentration: 560 nM
The estimate for compound 4 lay 3.1-fold (0.49 log units) below the measured number; the measured number falls inside the stated range.
By their numbers in this assay, from the lowest: compound 3; then compound 1; then compounds 2 and 4 (each within the scatter of the next).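

In this assay, for the compounds shown here, the 2-carboxypyridin-3-yl group gives the only large step at this position so far (a 12-fold higher number from compound 3 to compound 4 (1.09 log units; beyond the scatter)), and it also lies clear of the pyridin-4-yl group (a 5.5-fold higher number from compound 1 to compound 4 (0.74 log units; beyond the scatter)) while staying within the scatter of the 1H-1,2,3-triazol-1-yl group (a 1.4-fold higher number from compound 2 to compound 4 (0.16 log units; within the scatter)). A six-membered aromatic ring at this position therefore does not by itself keep the number low. No measurement shown here explains these steps.

The compounds shown do not separate the carboxylic acid from the change in how the pyridine is attached. A pyridin-3-yl group without the acid, or a methyl ester in its place, would address that.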